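Dropping the Methoxy from Compound 2: What to Expect

The source may hold more compounds than are shown below. What is called first, only, known or untested is meant among the compounds shown, and "the series" means these compounds.

Measured so far:
Compound 1, `O=C(NCCCCn1cccn1)c1cccc(C2SCC(=O)N2c2cccnc2)c1`: > 1000 nM
Compound 2, `COc1ccc(C)cc1N1C(=O)CSC1c1cccc(C(=O)NCCCCc2ccccc2)c1`: 300 nM
Compound 3, `CCOc1ccccc1N1C(=O)C(C)SC1c1cccc(C(=O)NCCCCc2ccccc2)c1`: 71.6 nM

In a functional assay on HOS-TE85 cells (Homo sapiens) for inhibition, read by CCK-8 assay, with a stated time of 72 h (a higher number here means a weaker inhibitor, a lower number a stronger inhibitor), compound 1 reports only a limit of the assay, not a number (the limit of > 1000 nM in this assay, at which 1 of the 3 values shown sits). Among the two actual numbers, compound 2 stands at the higher one, and compound 3 sits lower by a gap beyond the usual scatter.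

Compound 4, `Cc1cccc(N2C(=O)CSC2c2cccc(C(=O)NCCCCc3ccccc3)c2)c1`, is still to be measured in this assay. It differs from compound 2 in one place:
hydrogen in place of methoxy on an aromatic carbon
Within the data shown here, no measured pair shows this change by itself, so its size is uncertain. The step from compound 2 to compound 4 is expected to be a 2.0-fold higher number from compound 2 to compound 4 (0.30 log units; within the scatter), in the direction of a weaker inhibitor. Compound 4 is therefore estimated at 600 nM, within a range from 150 nM to 2500 nM.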

Compound 4, half-maximal inhibitory concentration: 93.2 nM
Beside the measured number, compound 4's estimate is 6.4-fold (0.81 log units) above it; the whole stated range lies above it.
By their numbers in this assay, from the lowest: compounds 3 and 4 (each within the scatter of the next); then compound 2. At a limit, above all of these: compound 1.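

In this assay, among these compounds, replacing the methoxy with hydrogen gives a 3.2-fold lower number from compound 2 to compound 4 (0.51 log units; beyond the scatter), the first reading of this change by itself. On this aromatic carbon, ortho to a large group, the methoxy is therefore not needed for activity in this pair, and the compound with hydrogen is the stronger inhibitor. Nothing measured here bears on why the number falls. Hydrogen is the only replacement shown at this position, so it remains open how a hydroxyl, a fluorine or an amine there would compare.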